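Swapping the anilide ring of compound 1 for a bromophenyl

The source may report more compounds than this note shows. Statements on the series, on what has been measured and on what is new or still open speak of the compounds shown alone.

Three compounds have been measured in an assay on HEK293 cells for binding affinity to Neuropeptide Y receptor type 5 (Homo sapiens), read by radioligand binding; on this read-out higher numbers stand for weaker inhibition and lower numbers for stronger inhibition:

compound 1 `Cc1cc(C(=O)Nc2cc(Cl)cc(Cl)c2)nn1-c1cccc(C(F)(F)F)c1`: 150 nM
compound 2 `Cc1cccc(-n2nc(C(=O)Nc3cc(Cl)cc(Cl)c3)cc2C)c1`: 218 nM
compound 3 `COc1cccc(-n2nc(C(=O)Nc3cc(Cl)cc(Cl)c3)cc2C)c1`: a limit of the assay, > 1000 nM

Among the two numbers, compound 1 has the lowest, with compound 2 nearest: a 1.5-fold higher number from compound 1 to compound 2 (0.16 log units; within the scatter), so the two cannot be ordered. Compound 3 sits at the limit of > 1000 nM in this assay, at which 1 of the 3 values shown sits. The steps of an at least 6.6-fold higher number from compound 1 to compound 3 (0.82 log units; beyond the scatter) and an at least 4.5-fold higher number from compound 2 to compound 3 (0.66 log units; beyond the scatter) are the only ones beyond the scatter, and all three measured steps vary the substituent on the aryl ring attached to the core, not the anilide.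

Compound 4 `Cc1cc(C(=O)Nc2cccc(Br)c2)nn1-c1cccc(C(F)(F)F)c1` differs from compound 1 elsewhere: 3-bromophenyl in place of 3,5-dichlorophenyl on an amide-type nitrogen. Within the data shown here, no measured step bears on this position, so the expectation rests on compound 1 alone, with wide uncertainty. Compound 4 is estimated at 400 nM, between 120 nM and 1500 nM. This estimate means the step of a 2.7-fold higher number from compound 1 to compound 4 (0.43 log units; beyond the scatter) in this assay, expected weaker but not beyond what a single untested change could produce.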

Compound 4, half-maximal inhibitory concentration: 359 nM
The estimate for compound 4 lay 1.1-fold (0.05 log units) above the measured number; measured number inside the range.
By their numbers in this assay, from the lowest: compounds 1, 2 and 4 (each within the scatter of the next, the first and the last beyond it). At a limit, above all of these: compound 3.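

Among these compounds, with the substituents on the aryl ring attached to the core the only variation so far, compound 4 gives the first reading on the anilide side, and in this assay this position responds to change: a 2.4-fold higher number from compound 1 to compound 4 (0.38 log units; beyond the scatter). The step is modest, so a 3-bromophenyl on the amide-type nitrogen still gives a measured number rather than a limit of the assay. It swaps two chlorines for one bromine, so the effect of the halogen's identity cannot be separated from that of their number, and nothing at hand accounts for the step.

On these data alone, what a 3-chlorophenyl or a 3,5-dibromophenyl would give at this position remains open, as does the effect of a nitrile or an amine on this ring. Also open, as far as these compounds go, is whether the same change would give a similar step with the methyl group of compound 2 in place of the trifluoromethyl.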